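Adding a methyl group beside the urea of compound 1

A few compounds are considered here, and "the series" means these few. Any claim that something is new, unique, unknown or untested is made for them only; others in the source may bear on it.

Of the compounds shown here, three sharing one core have been tested in a functional assay on HepG2 cells (Homo sapiens) for inhibition, with a stated time of 72 h; a higher number here means a weaker inhibitor, a lower number a stronger inhibitor. Compound 1 `O=C(Nc1ccc(Cl)cc1)Nc1nc(Sc2c[nH]c3ccccc23)cc(N2CCCC2)n1` gives 7870 nM. Compound 2 `O=C(Nc1ccccc1)Nc1nc(Sc2c[nH]c3ccccc23)cc(N2CCN(Cc3ccccc3)CC2)n1` gives 8160 nM. Compound 3 `O=C(Nc1ccc(Cl)cc1)Nc1nc(Sc2c[nH]c3ccccc23)cc(N2CCCCC2)n1` gives 14800 nM. None of these three numbers is separated from the others beyond the usual scatter, so compound 1 cannot be placed above or below compound 2 or compound 3 on this evidence. Within the data shown here, the only step between two compounds that differ in a single place is a 1.9-fold higher number from compound 1 to compound 3 (0.27 log units; within the scatter), and it too stays within the scatter.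

Compound 4 `Cc1cc(Cl)ccc1NC(=O)Nc1nc(Sc2c[nH]c3ccccc23)cc(N2CCCC2)n1` is the next compound, and it differs from compound 1 by methyl in place of hydrogen on an aromatic carbon. The change turns the 4-chlorophenyl group into a 4-chloro-2-methylphenyl group. Among the measured compounds shown here, no measured pair among the three compounds involves a change at that ring, so the measured step from compound 1 to compound 3 does not bear on it, and nothing in the data points in either direction. The expectation for compound 4 in this assay is therefore a step of a 1.0-fold lower number from compound 1 to compound 4 (0.02 log units; within the scatter), meaning no shift beyond the scatter. Compound 4 is estimated at 7500 nM, within a range of 2500 nM to 22000 nM.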

Compound 4, half-maximal inhibitory concentration: 7150 nM
Estimate against measurement, compound 4: 1.0-fold (0.02 log units) above, within the range that was stated.
By their numbers in this assay, from the lowest: compounds 4, 1, 2 and 3 (each within the scatter of the next, the first and the last beyond it).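

In this assay, putting a methyl group on the 4-chlorophenyl group of compound 1, ortho to a large group and meta to the chloro group, gives a 1.1-fold lower number from compound 1 to compound 4 (0.04 log units; within the scatter) and so stays within the scatter. Among these compounds, the only earlier single-place step swapped pyrrolidin-1-yl for piperidin-1-yl, so this is the first reading at the ring that carries the chloro group, and it shows that this position accepts one added carbon without a shift that can be told from the scatter. No measurement is available that would explain this result.

As far as these compounds go, a single methyl group says little about what this position accepts in general, so it remains open whether an ethyl group, a methoxy group or a larger group such as phenyl would also leave the number within the scatter. Also open, from the compounds shown here alone, are an amine or a carboxylic acid at the same place, and whether a methyl group would behave in the same way on a phenyl ring without the chloro group.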